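A few compounds are considered here, and "the series" means these few. Any claim that something is new, unique, unknown or untested is made for them only; others in the source may bear on it.

In a functional assay on HeLa cells (Homo sapiens) for cytotoxicity, read by MTT assay, with a stated time of 24 h (on this read-out lower numbers stand for stronger inhibition and higher numbers for weaker inhibition), compound 1 `C=CC1=C(C(=O)NC(C)(C)C)C(c2ccc(OC)cc2)OC1` gives > 100000 nM, which is a limit of the assay rather than a measured number. Compound 2 `C=CC1=C(C(=O)Nc2ccccc2)C(c2ccc(F)cc2)OC1` likewise gives > 100000 nM, again a limit. On the numbers shown, compound 1 stands at the limit of > 100000 nM in this assay, at which 2 of the 2 values shown sit, with nothing more potent to compare it against. Compound 3 `C=CC1=C(C(=O)NCc2ccccc2)C(c2ccc(OC)cc2)OC1` has not yet been measured; it differs from compound 1 by benzyl in place of tert-butyl on an amide-type nitrogen. With everything measured so far sitting at the limit, no step beyond the scatter is expected, meaning a number no higher from compound 1 to compound 3 (the limit leaves the size open). Compound 3 is therefore expected at 100000 nM, within a range from 30000 nM to 300000 nM, most likely reported again as a limit.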

Compound 3, half-maximal inhibitory concentration: > 100000 nM
Compound 3: only a limit was reported; the forecaster's own chance of this, stated with the estimate: 85%; the middle value sits exactly at the limit.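

Compound 1 and compound 3 both sit at a limit, so no step can be read between them: the limit of > 100000 nM in this assay, at which 3 of the 3 values shown sit. The compounds shown leave open whether any structural change would give a measurable value.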